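The source may report more compounds than this note shows. Statements on the series, on what has been measured and on what is new or still open speak of the compounds shown alone.

Measured so far in an ADME assay on cells (Hepatocyte, Homo sapiens) for metabolic stability, with a stated time of 30 min; on this read-out higher numbers stand for a more stable compound and lower numbers for a less stable compound: compound 1 `O=c1cc(N2CCN(CC3CCC(O)CC3)CC2)sc2c([N+](=O)[O-])cc(C(F)(F)F)cc12` gives 72.7%; compound 2 `O=C(OC1CCC(CN2CCN(c3cc(=O)c4cc(C(F)(F)F)cc([N+](=O)[O-])c4s3)CC2)CC1)c1cccs1` gives 2.2%; compound 3 `COc1ccc(C(=O)OC2CCC(CN3CCN(c4cc(=O)c5cc(C(F)(F)F)cc([N+](=O)[O-])c5s4)CC3)CC2)cc1` gives 12.2%.

Compound 3 stands second highest of the three. Its nearest neighbour is compound 2, with a number 10 percentage points higher from compound 2 to compound 3 (within the scatter); its furthest is compound 1, with a number 60.5 percentage points lower from compound 1 to compound 3 (beyond the scatter).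

Compound 4 `O=C(OC1CCC(CN2CCN(c3cc(=O)c4cc(C(F)(F)F)cc([N+](=O)[O-])c4s3)CC2)CC1)c1ccncc1` differs from compound 3 in one place: pyridin-4-yl in place of 4-methoxyphenyl on a carbonyl carbon.

For the measured compounds named here, two steps bear on this. Replacing hydrogen on the oxygen by a carbonyl-bearing ring gave large drops, a number 70.5 percentage points lower from compound 1 to compound 2 (beyond the scatter) and a number 60.5 percentage points lower from compound 1 to compound 3 (beyond the scatter). Swapping one aromatic ring for another on the carbonyl carbon, however, gave a number 10 percentage points higher from compound 2 to compound 3 (within the scatter). Compound 4 keeps the carbonyl on the oxygen and changes only the ring, so the expected step in this assay is a number 2.2 percentage points lower from compound 3 to compound 4 (within the scatter), none beyond the scatter. Compound 4 is therefore estimated at 10%, expected between 2% and 25%.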

Compound 4, percent of the compound remaining: 1%
Compound 4: the middle estimate sits 9 percentage points above what was measured; the whole stated range lies above it.
By their numbers in this assay, from the lowest: compounds 4, 2 and 3 (each within the scatter of the next, the first and the last beyond it); then compound 1.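

In this assay, for the compounds shown here, the ring on the carbonyl carbon can matter, since a number 11.2 percentage points lower from compound 3 to compound 4 (beyond the scatter) is the first ring swap beyond the scatter, while pyridin-4-yl against thiophen-2-yl gives only a number 1.2 percentage points lower from compound 2 to compound 4 (within the scatter) for the same kind of change. A third ring-bearing carbonyl on the oxygen repeats the large loss, with a number 71.7 percentage points lower from compound 1 to compound 4 (beyond the scatter) in line with the two earlier drops. No measurement shown gives a reason for these steps.

Open, from the compounds shown here alone, is whether an acetyl group or a carbamate on that oxygen, in place of these aromatic carbonyl groups, stays as low as compounds 2, 3 and 4 or comes back toward compound 1.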